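Removing the Chloro Group of Compound 1: An Expectation

This account rests on a few compounds, and the source may have more. Where it says the series, first, only, none or still open, it means among the compounds named here.

Compound 1 `Nc1nc(O)c2c(n1)n(C1OC(CO)[C@@H](O)[C@H]1O)c(=O)n2Cc1ccc(Cl)cc1`: 15%
Compound 2 `C=CCn1c(=O)n(C2OC(CO[Si](C)(C)C(C)(C)C)[C@@H](O)[C@H]2O)c2nc(N)nc(O)c21`: 5%
Compound 3 `C=CCn1c(=O)n([C@H]2CO[C@@H](CO)C2)c2nc(N)nc(O)c21`: 10%

Of the compounds shown here, three that share a core have been tested in a functional assay on the whole organism (B cells) with Mus musculus as the target; on this read-out higher numbers stand for larger maximal responses and lower numbers for smaller maximal responses. In this assay compound 1 gives 15%, compound 3 gives 10%, and compound 2 gives 5%. All three responses are small, and the gaps between them lie within the usual scatter of repeated measurements, so none of the three can be set apart from the others on these numbers; compound 1 simply sits among them with a small maximal response. No two of these compounds differ in just one place, so no single structural step can be read from them.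

Compound 4 `Nc1nc(O)c2c(n1)n(C1OC(CO)[C@@H](O)[C@H]1O)c(=O)n2Cc1ccccc1` has not yet been measured. It differs from compound 1 in one place: hydrogen in place of chloro on an aromatic carbon. Put another way, the 4-chlorobenzyl group of compound 1 becomes a benzyl group in compound 4. Within the data shown here, nothing measured so far shows how such a change moves the response in this assay. Because compound 1 gives 15% and the other two measured responses lie small and close to it, a step of a number 3 percentage points lower from compound 1 to compound 4 (within the scatter) is expected, one that stays within the scatter and points in no firm direction. Compound 4 is therefore estimated to reach 12% in this assay, with a range from 3% to 30%.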

Compound 4, largest response reached (reported as maximal response), in percent of the reference or control that the assay uses: 110%
Beside the measured number, compound 4's estimate is 98 percentage points below it; the whole stated range lies below it.
By their numbers in this assay, from the lowest: compounds 2, 3 and 1 (each within the scatter of the next); then compound 4.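

Replacing the chloro of the 4-chlorobenzyl group with hydrogen, which leaves a plain benzyl group, is the only single-place change shown, and it gives a step of a number 95 percentage points higher from compound 1 to compound 4 (beyond the scatter) in this assay with the rest of the structure unchanged. The earlier compounds shown here differ from one another in more than one place and lie within the scatter of each other, so they could not show that this aromatic carbon matters so much: here, the loss of one chlorine atom separates a small maximal response from a large one. Nothing in the data shown bears on why this change has so large an effect.

Going by these compounds, it remains open whether a large response needs hydrogen on this carbon, or whether other groups in its place, such as fluoro, methyl, methoxy, an amine or a carboxylic acid, would keep it or lose it. Also open, on these data alone, is how much depends on the benzyl group as a whole, for instance whether a longer chain such as 2-phenylethyl would give a similar response.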